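Fluoro to trifluoromethyl at the assay limit

A few compounds are considered here, and "the series" means these few. Any claim that something is new, unique, unknown or untested is made for them only; others in the source may bear on it.

In an ADME assay on THP-1 cells (Homo sapiens) for cytotoxicity, read by flow cytometry and propidium iodide staining, with a stated time of 72 h (a higher number here means a weaker inhibitor, a lower number a stronger inhibitor), compound 1 `COc1c(-c2ccccc2)oc2ccc(NC(C)=O)cc2c1=O` gives > 125000 nM, which is a limit of the assay and not a number. Compound 2 `COc1c(-c2cccc(F)c2)oc2ccc(NC(C)=O)cc2c1=O` gives > 125000 nM, likewise only a limit, so its standing can be told no more closely. Compound 3 `COc1c(-c2cccc(C(F)(F)F)c2)oc2ccc(NC(C)=O)cc2c1=O` carries trifluoromethyl in place of fluoro on an aromatic carbon, meta to a large group (trifluoromethyl in place of fluoro on an aromatic carbon). For the measured compounds named here, the only measured step that bears on this change is a step that the two limits leave unreadable from compound 1 to compound 2, with fluoro in place of hydrogen on an aromatic carbon. Going by the values given here, its size cannot be read, and no measured compound carries trifluoromethyl. Compound 2 stands with the limit of > 125000 nM in this assay, at which 2 of the 2 values shown sit, so no step beyond the scatter is expected in this assay. The expected a number no higher from compound 2 to compound 3 (the limit leaves the size open) is an estimate resting on little. For compound 3 the estimated value is 125000 nM, with an expected range of 50000 nM to 200000 nM.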

Compound 3, half-maximal inhibitory concentration: 52000 nM
The estimate for compound 3 lay 2.4-fold (0.38 log units) above the measured number, and the stated range covers the measured number.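

At this aromatic carbon, trifluoromethyl brings a measurable reading into this assay, which neither hydrogen nor fluoro had given. The change from fluoro gives an at least 2.4-fold lower number from compound 2 to compound 3 (0.38 log units; beyond the scatter), and the change from hydrogen gives an at least 2.4-fold lower number from compound 1 to compound 3 (0.38 log units; beyond the scatter); both sizes are lower bounds, and the step between hydrogen and fluoro cannot be read. Compound 3 is thus the only one of the three with a number rather than a limit: the limit of > 125000 nM in this assay, at which 2 of the 3 values shown sit.

The compounds shown leave open how far compound 1 and compound 2 actually lie from compound 3, and whether a nitrile, an amine or a carboxylic acid on this same carbon would also give a reading. They also leave open whether trifluoromethyl elsewhere on this ring would do the same.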